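Chloro for methyl: a small change on the shared core

The source may report more compounds than this note shows. Statements on the series, on what has been measured and on what is new or still open speak of the compounds shown alone.

compound 1 `O=C(Nc1ccc(C(F)(F)F)cc1)c1cc(Cl)ccc1O`: 510 nM
compound 2 `COc1cccc(C(=O)Nc2ccc(C#N)cc2)c1O`: > 10000 nM
compound 3 `Cc1ccc(O)c(C(=O)Nc2ccc(C#N)cc2)c1`: 3920 nM

In a functional assay on HL-60 cells (Homo sapiens) for cytotoxicity, read by luminescence and CellTiter-Glo, with a stated time of 3 days (on this read-out lower numbers stand for stronger inhibition and higher numbers for weaker inhibition), compound 1 gives 510 nM. For compound 2 the result is only a limit of the assay, > 10000 nM. Compound 3 gives 3920 nM, the higher of the two plain numbers, and compound 1 sits well below it, beyond the scatter. Compound 4 `N#Cc1ccc(NC(=O)c2cc(Cl)ccc2O)cc1` has not yet been measured. It differs from compound 3 in one place: chloro in place of methyl on an aromatic carbon. Among the compounds with values here, compound 1 also carries a chloro at that place, but its other ring differs as well, so no single step shows what the swap alone does. A modest move toward stronger inhibition is expected for compound 4, a 2.2-fold lower number from compound 3 to compound 4 (0.34 log units; beyond the scatter), possibly no larger than the scatter. Compound 4 is estimated at 1800 nM, within 450 nM to 7000 nM.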

Compound 4, half-maximal inhibitory concentration: 700 nM
The estimate for compound 4 lay 2.6-fold (0.41 log units) above the measured number, within the range that was stated.
By their numbers in this assay, from the lowest: compounds 1 and 4 (each within the scatter of the next); then compound 3. At a limit, above all of these: compound 2.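

Chloro in place of methyl, on the carbon para to a hydroxy group, gives a 5.6-fold lower number from compound 3 to compound 4 (0.75 log units; beyond the scatter) and so stands as the first reading of this swap alone, since compound 1 also differs from compound 3 on its other ring. Cyano in place of trifluoromethyl gives a 1.4-fold higher number from compound 1 to compound 4 (0.14 log units; within the scatter) on the same chloro-bearing core, so these two groups cannot be told apart here. From the compounds shown here alone, whether the result holds on other cores remains untested by these compounds.

Going by these compounds, how an amine or a carboxylic acid would behave at this position stays open. Nothing shown explains the effect of the swap.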